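One Methyl Stereocentre Tested in Growth Inhibition

The compounds below may be only part of what the source reports. "The series", "measured", "known", "first", "only" and "open" are said of these compounds alone.

In a functional assay on MV4-11 cells (Homo sapiens) for inhibition, read by luminescence, with a stated time of 3 days (on this read-out higher numbers stand for weaker inhibition of growth and lower numbers for stronger inhibition of growth), compound 1 `CC(=O)N1CCN(C(=O)[C@@H]2CC[C@@H](C)N2C(=O)C2=C(C(C)C)N3C(=N[C@@](C)(c4ccc(Cl)cc4)[C@H]3c3ccc(Cl)cc3)S2)CC1` gives 270 nM. Compound 2 `CC(=O)N1CCN(C(=O)[C@@H]2CC[C@@H](C)N2C(=O)C2=C(C(C)C)N3C(=N[C@@](C)(c4ccc(Cl)cc4)[C@H]3c3ccc(Cl)cc3)S2)C[C@H]1C` gives 83 nM, the lower of the two numbers. Compound 3 `CC(=O)N1CCN(C(=O)[C@@H]2CC[C@@H](C)N2C(=O)C2=C(C(C)C)N3C(=N[C@@](C)(c4ccc(Cl)cc4)[C@H]3c3ccc(Cl)cc3)S2)C[C@@H]1C` has not yet been measured. Its difference from compound 2 is the two compounds have the same atoms and bonds and differ only in configuration as drawn: 1 of 5 stereo elements differ; a stereocentre at a saturated ring carbon is drawn R in compound 2 and S in compound 3, with a stereocentre at a saturated ring carbon drawn R in compound 2 and S in compound 3. Going by the values given here, only one measured step bears on this change: a 3.3-fold lower number from compound 1 to compound 2 (0.51 log units; beyond the scatter), a modest step that came with a methyl in place of hydrogen on a saturated ring carbon. Among the compounds with values here, that step shows one drawn configuration only, and no measurement yet shows the other. A higher number is therefore expected, giving back part or most of that step. The expected change is a 2.2-fold higher number from compound 2 to compound 3 (0.34 log units; beyond the scatter). The estimate for compound 3 is 180 nM, within an expected range of 60 nM to 500 nM.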

Compound 3, concentration for 50% growth inhibition: 400 nM
Compound 3: middle estimate off by 2.2-fold (0.35 log units), on the low side; low and high end bracket the measured number.
By their numbers in this assay, from the lowest: compound 2; then compounds 1 and 3 (each within the scatter of the next).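

The methyl on this saturated ring carbon does not count the same in both drawn configurations. With the S configuration there is a 1.5-fold higher number from compound 1 to compound 3 (0.17 log units; within the scatter), so in this assay the earlier gain is confined to the R configuration, while changing R to S gives a 4.8-fold higher number from compound 2 to compound 3 (0.68 log units; beyond the scatter). That second step can be put down to this single stereocentre alone because nothing else separates the pair: the fact that compounds 2 and 3 differ only in the configuration as drawn.

The compounds shown do not tell whether an ethyl or a hydroxymethyl group on the same carbon would keep the same dependence on configuration. Nor do they tell whether that dependence would survive if a different acyl group took the place of the acetyl group on the ring.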